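Diacid Side Chain on a Weakly Antiproliferative Amide Core

A few compounds are considered here, and "the series" means these few. Any claim that something is new, unique, unknown or untested is made for them only; others in the source may bear on it.

Compound 1 `CCn1c(C(=O)N[C@@H](C)C(=O)OC)ccc1C(CC)(CC)c1ccc(OCS(=O)(=O)c2ccccc2)c(C)c1` gives 43700 nM in a functional assay on MCF7 cells (Homo sapiens) for antiproliferative activity, read by MTT assay, with a stated time of 24 h; on this read-out lower numbers stand for stronger inhibition and higher numbers for weaker inhibition.
Compound 2 `CCn1c(C(=O)N[C@@H](CC(=O)OC)C(=O)OC)ccc1C(CC)(CC)c1ccc(OCS(=O)(=O)c2ccccc2)c(C)c1` reaches only the limit of this assay, > 50000 nM.
Compound 3 `CCn1c(C(=O)NCCCO)ccc1C(CC)(CC)c1ccc(OCS(=O)(=O)c2ccccc2)c(C)c1` gives 42000 nM in this assay.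

All three compounds share one core and differ only in the group on the amide-type nitrogen. Compound 3 holds the lower of the two measured numbers, but compound 1 sits within the scatter of it, so the two cannot be told apart. The steps along this nitrogen substituent are all small: a 1.0-fold lower number from compound 1 to compound 3 (0.02 log units; within the scatter), an at least 1.1-fold lower number from compound 2 to compound 3 (0.07 log units; that floor lies within the scatter), and an at least 1.1-fold higher number from compound 1 to compound 2 (0.05 log units; that floor lies within the scatter), the last resting on the limit described by the limit of > 50000 nM in this assay, at which 1 of the 3 values shown sits.

Compound 4 `CCn1c(C(=O)N[C@H](CCC(=O)O)C(=O)O)ccc1C(CC)(CC)c1ccc(OCS(=O)(=O)c2ccccc2)c(C)c1` changes the same position: 1,3-dicarboxypropyl in place of 3-hydroxypropyl on an amide-type nitrogen. The earlier swaps at this nitrogen, from an ester-bearing chain to a hydroxy chain and from one ester to two, moved the number little or not at all, so no step beyond the scatter is expected here either; if anything, a drift toward the limit is expected, as compound 2 reached it. The expected step is a 1.1-fold higher number from compound 3 to compound 4 (0.04 log units; within the scatter). Compound 4 is therefore estimated at 46000 nM, within a range from 22000 nM to 95000 nM.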

Compound 4, half-maximal inhibitory concentration: > 50000 nM
Compound 4: a limit, no number; the forecaster's own chance of this, stated with the estimate: 45%; at least 1.0-fold (0.03 log units) between middle value and limit.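

The 1,3-dicarboxypropyl group of compound 4 is the only group shown on the amide-type nitrogen that carries free carboxylic acids, and in this assay compound 4 gives > 50000 nM, a limit and not a number. Against the two compounds with readable numbers, only floors can be given, an at least 1.1-fold higher number from compound 3 to compound 4 (0.07 log units; that floor lies within the scatter) and an at least 1.1-fold higher number from compound 1 to compound 4 (0.05 log units; that floor lies within the scatter), so neither comparison shows a real change, and the step between compound 2 and compound 4 cannot be read. This position has now carried a hydroxy chain, ester-bearing chains and a chain with two carboxylic acids without any readable step beyond the scatter, and the top of the range is filling up: the limit of > 50000 nM in this assay, at which 2 of the 4 values shown sit.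

From the compounds shown here alone, whether the 1,3-dicarboxypropyl group of compound 4 and the 1,2-bis(methoxycarbonyl)ethyl group of compound 2 truly differ in this assay stays open. Also open, going by these compounds, is whether an amine or a longer chain on this nitrogen would give a number clearly lower than those of compound 1 and compound 3.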